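Amide variants and a small step in prospect

A few compounds are considered here, and "the series" means these few. Any claim that something is new, unique, unknown or untested is made for them only; others in the source may bear on it.

Compound 1 `CCn1c(C(=O)NCCN)ccc1C(CC)(CC)c1ccc(OCCC(O)(CC)CC)c(C)c1`: 2940 nM
Compound 2 `C#CCCOC(=O)c1ccc(C(CC)(CC)c2ccc(OCCC(O)(CC)CC)c(C)c2)n1CC`: > 50000 nM (a limit of the assay, not a number)
Compound 3 `CCn1c(C(=O)NC(CC(=O)O)C(=O)OC)ccc1C(CC)(CC)c1ccc(OCCC(O)(CC)CC)c(C)c1`: 7590 nM

In an ADME assay on L02 cells (Homo sapiens) for antiproliferative activity, read by MTT assay, with a stated time of 48 h (a higher number here means a weaker inhibitor, a lower number a stronger inhibitor), compound 3 has the higher of the two true numbers, with compound 1 as its nearest neighbour. Compound 4 `CCn1c(C(=O)N(C)CCO)ccc1C(CC)(CC)c1ccc(OCCC(O)(CC)CC)c(C)c1` differs from compound 3 on a carbonyl carbon: a group of 5 heavy atoms (3 carbon, 1 nitrogen, 1 oxygen; no ring) in place of a group of 10 heavy atoms (5 carbon, 1 nitrogen, 4 oxygen; no ring), on a carbonyl carbon. The entering group is (2-hydroxyethyl)(methyl)amino.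

Going by the values given here, two measured steps bear on this. Changing the group on the amide-type nitrogen gave only a 2.6-fold higher number from compound 1 to compound 3 (0.41 log units; beyond the scatter). Replacing the nitrogen-linked group with (but-3-yn-1-yl)oxy gave an at least 17-fold higher number from compound 1 to compound 2 (1.23 log units; beyond the scatter). Compound 4 keeps a nitrogen on that carbonyl carbon, so no step beyond the scatter is expected, and the expected step is a 1.2-fold higher number from compound 3 to compound 4 (0.07 log units; within the scatter). The estimated value for compound 4 is 9000 nM, within an expected range from 3000 nM to 30000 nM.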

Compound 4, half-maximal inhibitory concentration: 2050 nM
Estimate against measurement, compound 4: 4.4-fold (0.64 log units) above; the whole stated range lies above it.
By their numbers in this assay, from the lowest: compounds 4 and 1 (each within the scatter of the next); then compound 3. At a limit, above all of these: compound 2.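

In this assay, (2-hydroxyethyl)(methyl)amino on this carbonyl carbon performs on a par with (2-aminoethyl)amino, a 1.4-fold lower number from compound 1 to compound 4 (0.16 log units; within the scatter), so the terminal amine is not needed to hold this level. Nitrogen-linked groups are still not all alike here: the smaller group gives a 3.7-fold lower number from compound 3 to compound 4 (0.57 log units; beyond the scatter). Replacing (but-3-yn-1-yl)oxy gives an at least 24-fold lower number from compound 2 to compound 4 (1.38 log units; beyond the scatter), a step that starts from a limit of the assay, not a number: the limit of > 50000 nM in this assay, at which 1 of the 4 values shown sits.

On these data alone, whether the nitrogen-linked group needs its hydroxyl remains open. So does how a piperidine ring on this carbonyl carbon would compare.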